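From piperidine to cyclopentyl ether: a solubility estimate

A few compounds are considered here, and "the series" means these few. Any claim that something is new, unique, unknown or untested is made for them only; others in the source may bear on it.

Compound 1 `CC1CCCN(c2cc(C(F)(F)F)nn2-c2ccc(S(C)(=O)=O)cn2)C1`: "not determined" (no result reported)
Compound 2 `CC1CCCN(c2c(C#N)c(C(F)(F)F)nn2-c2ccc(S(C)(=O)=O)cn2)C1`: 100 ug/mL
Compound 3 `CC(C)(C)CNc1c(C#N)c(C(F)F)nn1-c1ccc(S(C)(=O)=O)cc1`: > 200 ug/mL

All three entries come from a physicochemical assay for solubility; a higher number here means a more soluble compound, a lower number a less soluble compound. In this assay compound 1 has no number to stand on, its entry being "not determined" (no result reported). Going by the values given here, the only plain number is held by compound 2, at 100 ug/mL. Compound 3 reads > 200 ug/mL, and this is a limit of this assay, not a number.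

Compound 4 `CS(=O)(=O)c1ccc(-n2nc(C(F)(F)F)cc2OC2CCCC2)nc1` has not yet been measured. The change under consideration is cyclopentyloxy in place of 3-methylpiperidin-1-yl on an aromatic carbon. In words, cyclopentyloxy stands in place of 3-methylpiperidin-1-yl on an aromatic carbon, next to the ring nitrogen, while the rest of the core of compound 1 stays as it is.

Among the compounds with values here, no measured pair in this set shows this exchange, and compound 1 offers no starting value, so no step can be carried across. Any step in this assay can only be guessed, and none beyond the usual scatter is expected from the exchange alone. Within the data shown here, the expectation for the new compound therefore leans on compound 2 at 100 ug/mL, the one plain number available, and is set somewhat under it, with a wide margin. For compound 4 the estimated value is 50 ug/mL, with an expected range from 10 ug/mL to 170 ug/mL.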

Compound 4, solubility: 50 ug/mL
Compound 4: the middle estimate sits on the measured number at the digits printed; measured number inside the range.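

In this assay, going by these compounds alone, compound 1 stands as "not determined" (no result reported) and offers no number to set against compound 4, so no step between the two can be read. The compounds shown leave open what cyclopentyloxy in place of 3-methylpiperidin-1-yl does to solubility on the shared core. Nothing shown here bears on the value of compound 4.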